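The source may report more compounds than this note shows. Statements on the series, on what has been measured and on what is new or still open speak of the compounds shown alone.

Compound 1 `CC(=O)Nc1ccc(-c2cccc(C(=O)N[C@H]3CN[C@@H](C(=O)Nc4ccc(Cl)c(C(F)(F)F)c4)C3)c2)cn1` gives 8710 nM in a functional assay on K562 cells (Homo sapiens) for inhibition, read by MTT assay, with a stated time of 48 h; on this read-out lower numbers stand for stronger inhibition and higher numbers for weaker inhibition. Compound 2 `CS(=O)(=O)Nc1ccc(-c2cccc(C(=O)N[C@H]3CN[C@@H](C(=O)Nc4ccc(Cl)c(C(F)(F)F)c4)C3)c2)cn1` gives 24600 nM in this assay. Compound 3 `C[C@H](NC(=O)c1ccc(-c2ccc(NS(C)(=O)=O)nc2)cc1)C(=O)Nc1ccc(Cl)c(C(F)(F)F)c1` gives 7240 nM in this assay.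

Compound 4 `CC(=O)Nc1ccc(-c2ccc(C(=O)N[C@@H](C)C(=O)Nc3ccc(Cl)c(C(F)(F)F)c3)cc2)cn1` has not yet been measured in this assay. It differs from compound 3 by acetyl in place of methylsulfonyl on a nitrogen on an aromatic ring. The same change, at the same place, has already been made from compound 2 to compound 1: acetyl in place of methylsulfonyl on a nitrogen on an aromatic ring. That step gave a 2.8-fold lower number from compound 2 to compound 1 (0.45 log units; beyond the scatter). The difference between the core of compound 2 and the core of compound 3 is not broken down here. Compound 1 and compound 3 lie within the scatter of each other, while compound 2 gives a higher number than compound 3, beyond the scatter. If the change carries over to the core of compound 3, compound 4 is expected to show a 2.4-fold lower number from compound 3 to compound 4 (0.38 log units; beyond the scatter), an expectation resting on the measured pair a 2.8-fold lower number from compound 2 to compound 1 (0.45 log units; beyond the scatter). Compound 4 is therefore estimated at 3000 nM, with a likely range from 1200 nM to 7500 nM.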

Compound 4, half-maximal inhibitory concentration: 107000 nM
Estimate against measurement, compound 4: 36-fold (1.55 log units) below, and the stated range ends below it.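

In this assay replacing methylsulfonyl with acetyl on the nitrogen gave a 15-fold higher number from compound 3 to compound 4 (1.17 log units; beyond the scatter) and so ran opposite to the earlier step on the other core. The change therefore did not carry over between these two cores, in either direction or size: the same change on two cores in this assay, a 2.8-fold lower number (0.45 log units; beyond the scatter) from compound 2 to compound 1 and a 15-fold higher number (1.17 log units; beyond the scatter) from compound 3 to compound 4, 42-fold (1.62 log units) apart, beyond the scatter of two such steps. Going by these compounds alone, this does not show which part of the cores lies behind the reversal, and with only one pair on each core it gives no general rule for the series.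

The compounds shown leave open how a free amine or a longer acyl chain such as propanoyl on this nitrogen would behave on either core. They also leave open whether ethylsulfonyl would follow methylsulfonyl.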